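Compound 1 chain change: 2-hydroxyethyl to 3-methoxypropyl

The source may report more compounds than this note shows. Statements on the series, on what has been measured and on what is new or still open speak of the compounds shown alone.

In a toxicity assay on CHO-K1 cells (Cricetulus griseus) for cytotoxicity, read by MTT assay, with a stated time of 48 h (on this read-out higher numbers stand for weaker inhibition and lower numbers for stronger inhibition), compound 1 `COc1cc(/C=C/C(=O)/C=C(/C=C/c2ccc(O)c(OC)c2)NCCO)ccc1O` gives 87500 nM, the highest of three numbers. Compound 3 `O=C(/C=C(/C=C/c1ccc(O)cc1)NCCO)/C=C/c1ccc(O)cc1` gives 66000 nM, within the scatter of compound 1, and compound 2 `O=C(/C=C(/C=C/c1ccc(O)cc1)NCCCO)/C=C/c1ccc(O)cc1` gives 39100 nM, beyond it.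

Compound 4 `COCCCNC(=C\C(=O)/C=C/c1ccc(O)c(OC)c1)/C=C/c1ccc(O)c(OC)c1` differs from compound 1 by methoxymethyl in place of hydroxy on a saturated chain carbon, two bonds along the chain from an amine nitrogen.

Going by the values given here, one measured step bears on this place: a 1.7-fold higher number from compound 2 to compound 3 (0.23 log units; within the scatter). Among the compounds with values here, it stays within the scatter, and no measured compound carries the methoxy end.

No step beyond the scatter is expected in this assay, with at most a slight drift to a lower number: the estimated change is a 1.3-fold lower number from compound 1 to compound 4 (0.13 log units; within the scatter).

Compound 4 is estimated at 65000 nM, with an expected range of 30000 nM to 140000 nM.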

Compound 4, half-maximal inhibitory concentration: 53700 nM
For compound 4 the middle estimate is 1.2-fold (0.08 log units) above the measured one, and the stated range covers the measured number.
By their numbers in this assay, from the lowest: compounds 2, 4, 3 and 1 (each within the scatter of the next, the first and the last beyond it).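

In this assay, a 1.6-fold lower number from compound 1 to compound 4 (0.21 log units; within the scatter), so going from 2-hydroxyethyl to 3-methoxypropyl on the amine stays within the scatter, even though the hydrogen-bond donor of the hydroxy leaves. With a 1.7-fold higher number from compound 2 to compound 3 (0.23 log units; within the scatter) also within the scatter, neither measured change on this chain moves the number beyond it. Nothing measured here gives a reason for the new step.

Still open, from the compounds shown here alone, is whether a chain ending in an amine or a carboxylic acid, or a longer chain, would stay within the scatter. Going by these compounds, whether the methoxy end behaves the same way on the core of compound 2 is also open.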